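A Pyridine Ring Replaces Phenyl on an Amide Nitrogen

A few compounds are considered here, and "the series" means these few. Any claim that something is new, unique, unknown or untested is made for them only; others in the source may bear on it.

Of the compounds shown here, three sharing one core have been tested in an ADME assay on RAW264.7 cells (Mus musculus) for cytotoxicity, read by MTT assay, with a stated time of 72 h, tested at 50 uM; on this read-out lower numbers stand for a weaker effect and higher numbers for a stronger effect at the one concentration tested. Compound 1 `O=C(Cn1c(=O)oc2ccccc21)NCc1ccccn1` gives 37.3%, compound 2 `O=C(Cn1c(=O)oc2ccccc21)NCc1cccs1` gives 23.4%, and compound 3 `O=C(Cn1c(=O)oc2ccccc21)Nc1ccccc1` gives 35.1%. On these numbers compound 3 stands second highest of the three: its nearest neighbour is compound 1, within the scatter, and its furthest is compound 2, beyond it. The steps measured so far are a number 13.9 percentage points lower from compound 1 to compound 2 (beyond the scatter), a number 2.2 percentage points lower from compound 1 to compound 3 (within the scatter) and a number 11.7 percentage points higher from compound 2 to compound 3 (beyond the scatter).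

Compound 4 `O=C(Cn1c(=O)oc2ccccc21)Nc1ccccn1` differs from compound 3 as follows: pyridin-2-yl in place of phenyl on an amide-type nitrogen. Among the compounds with values here, the step that bears most on this is the one from compound 1 to compound 3, where a pyridin-2-yl group with a chain carbon and a plain phenyl gave numbers within the scatter of each other; only the thiophene of compound 2 stood clearly apart. A pyridine ring on the amide nitrogen is therefore expected to leave the read-out roughly where compound 3 sits, an estimated a number 2.9 percentage points higher from compound 3 to compound 4 (within the scatter), within the scatter. Compound 4 is estimated at 38%, with a range from 26% to 50%.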

Compound 4, a percentage reported as inhibition, at one concentration (the size of the read-out at that concentration, not a potency): 20.2%
The estimate for compound 4 lay 17.8 percentage points above the measured number, outside the stated range (below it).
By their numbers in this assay, from the lowest: compounds 4 and 2 (each within the scatter of the next); then compounds 3 and 1 (each within the scatter of the next).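

In this assay, within the data shown here, the ring on the amide-type nitrogen matters more than the earlier compounds suggested: pyridin-2-yl in place of phenyl, the same ring size with one carbon traded for a nitrogen, gives a number 14.9 percentage points lower from compound 3 to compound 4 (beyond the scatter). Keeping the pyridin-2-yl ring but dropping its chain carbon gives a number 17.1 percentage points lower from compound 1 to compound 4 (beyond the scatter), so this ring reads differently with and without that carbon. Against the thiophene compound the result is a number 3.2 percentage points lower from compound 2 to compound 4 (within the scatter), and no evidence at hand explains any of these steps.

Still open, from the compounds shown here alone, is whether the lower number follows the ring nitrogen itself or its place in the ring, which a pyridin-3-yl or pyridin-4-yl group on the same nitrogen could test. A benzyl group, a phenyl ring on a chain carbon, would show how a carbon-only ring responds to that same extra carbon.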